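The compounds below may be only part of what the source reports. "The series", "measured", "known", "first", "only" and "open" are said of these compounds alone.

Measured so far:
- compound 1 `CCc1ccc(SCc2ccc(C(=O)Nc3ccccc3N)cc2)cc1`: 91.4%
- compound 2 `CC(C)(C)c1ccc(SCc2ccc(C(=O)Nc3ccccc3N)cc2)cc1`: 67%

In a functional assay on A549 cells (Homo sapiens) for inhibition, read by CCK-8 assay, with a stated time of 72 h, tested at 8 uM (on this read-out lower numbers stand for less inhibition of growth and higher numbers for more inhibition of growth at the one concentration tested), compound 2 has the lower of the two numbers, at 67%. The next compound, compound 3 `Nc1ccccc1NC(=O)c1ccc(CSc2ccc(Cl)cc2)cc1`, keeps the core of compound 2 and has chloro in place of tert-butyl on an aromatic carbon.

Within the data shown here, only one measured step bears on this change. It is a number 24.4 percentage points lower from compound 1 to compound 2 (beyond the scatter), and it came with tert-butyl in place of ethyl on that same aromatic carbon. Here the tert-butyl group leaves instead of entering, so a move in the opposite direction is expected, although chloro has not yet been measured on this core. The expected rise is a number 18 percentage points higher from compound 2 to compound 3 (beyond the scatter), of similar size to the measured step. For compound 3 the estimated value is 85%, with an expected range of 68% to 97%.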

Compound 3, percent growth inhibition at one concentration: 50.4%
For compound 3 the middle estimate is 34.6 percentage points above the measured one; the measured number lies below the stated range.
By their numbers in this assay, from the lowest: compound 3; then compound 2; then compound 1.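

The position is more sensitive to its substituent than the first pair could show: losing tert-butyl does not by itself restore growth inhibition in this assay. Chloro gives a number 16.6 percentage points lower from compound 2 to compound 3 (beyond the scatter), and against ethyl it gives a number 41 percentage points lower from compound 1 to compound 3 (beyond the scatter), so the three groups now span a wide range at a single site. The number does not simply rise as the group shrinks, since ethyl gives the highest value while chloro, with 1 heavy atom, falls below tert-butyl, with 4 heavy atoms, and no measurement here explains this order.

As far as these compounds go, whether a longer chain such as propyl, or a methoxy group, would stay close to ethyl remains open. So does whether an amine or a carboxylic acid at this position would be tolerated at all.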